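Swapping cyclopropyl for methylamino on a sulfonyl sulfur

The source may report more compounds than this note shows. Statements on the series, on what has been measured and on what is new or still open speak of the compounds shown alone.

Of the compounds shown here, two built on one shared core have so far been tested in a physicochemical assay for solubility, measured as kinetic solubility; on this read-out higher numbers stand for higher solubility and lower numbers for lower solubility. Compound 1 `Cc1cnc(NC(=O)c2cc(Oc3ccc(C(=O)N(C)C)cc3)c3cn(C)nc3c2)cn1` gives 351000 nM. Compound 2 `Cc1cnc(NC(=O)c2cc(Oc3ccc(S(=O)(=O)C4CC4)cc3)c3cn(C)nc3c2)cn1` gives 73000 nM, the lower of the two numbers. For the measured compounds named here, putting cyclopropylsulfonyl in place of dimethylcarbamoyl on an aromatic carbon accounts for the only measured step, a 4.8-fold lower number from compound 1 to compound 2 (0.68 log units; beyond the scatter).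

Compound 3 `CNS(=O)(=O)c1ccc(Oc2cc(C(=O)Nc3cnc(C)cn3)cc3nn(C)cc23)cc1` has not yet been measured. It keeps everything in compound 2 except one small piece: methylamino in place of cyclopropyl on a sulfonyl sulfur. In words, methylamino stands in place of cyclopropyl on a sulfonyl sulfur, which turns cyclopropylsulfonyl into methylsulfamoyl.

Going by the values given here, no measured pair shows this exact change, so the forecast rests on thin evidence. The nearest guide is the modest step of a 4.8-fold lower number from compound 1 to compound 2 (0.68 log units; beyond the scatter), which exchanged an entire group on an aromatic carbon, whereas here only the part on the sulfur changes. A smaller move is therefore expected, with no shift beyond the scatter and only a slight lean upward. The expected change is a 1.4-fold higher number from compound 2 to compound 3 (0.14 log units; within the scatter). For compound 3 the estimated value is 100000 nM, with an expected range of 35000 nM to 280000 nM.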

Compound 3, solubility: 27000 nM
Estimate against measurement, compound 3: 3.7-fold (0.57 log units) above, outside the stated range (below it).
By their numbers in this assay, from the lowest: compound 3; then compound 2; then compound 1.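

In this assay, the small piece on the sulfonyl sulfur matters on its own: with everything else held fixed, methylamino in place of cyclopropyl gives a 2.7-fold lower number from compound 2 to compound 3 (0.43 log units; beyond the scatter), so even this limited exchange moves the number beyond the scatter. The earlier step replaced a whole group on the aromatic carbon, so it could not separate the effect of the sulfonyl from that of whatever the sulfonyl carries, whereas the new exchange at that carbon, methylsulfamoyl in place of dimethylcarbamoyl, gives a 13-fold lower number from compound 1 to compound 3 (1.11 log units; beyond the scatter) and shows that the two sulfonyl-containing groups can stand well apart from each other in their distance from compound 1. Nothing measured here accounts for the fall seen with methylamino.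

The compounds shown carry just two groups on the sulfonyl sulfur, so it remains open whether the drop follows the nitrogen, the hydrogen on that nitrogen, or the departure of the cyclopropyl ring. A dimethylamino group on the sulfur, which has no hydrogen on its nitrogen, or a plain methyl group, which has no nitrogen and no ring, would help to pull these possibilities apart.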